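Shortening the Ester Chain and Closing It into a Ring

The source may hold more compounds than are shown below. What is called first, only, known or untested is meant among the compounds shown, and "the series" means these compounds.

Of the compounds shown here, three sharing one core have been measured in a functional assay on HeLa cells (Homo sapiens) for cytotoxicity, read by MTT assay; on this read-out higher numbers stand for weaker inhibition and lower numbers for stronger inhibition. Compound 1 `CC(=O)OCCO[C@H](CC=C(C)C)C1=CC(=O)c2c(O)ccc(O)c2C1=O` gives 41500 nM. Compound 2 `CC[C@](C)(O)CC(=O)O[C@H](CC=C(C)C)C1=CC(=O)c2c(O)ccc(O)c2C1=O` gives 30200 nM, a change of a 1.4-fold lower number from compound 1 to compound 2 (0.14 log units; within the scatter). Compound 3 `CCCCCCC(C)(O)CC(=O)O[C@H](CC=C(C)C)C1=CC(=O)c2c(O)ccc(O)c2C1=O` reaches > 100000 nM, which is a limit of the assay and not a number. Compound 3 therefore stands at the limit of > 100000 nM in this assay, at which 1 of the 3 values shown sits, set apart from the other two by an at least 3.3-fold higher number from compound 2 to compound 3 (0.51 log units; beyond the scatter). Compound 4 `CC(C)=CC[C@@H](OC(=O)C1CCCCO1)C1=CC(=O)c2c(O)ccc(O)c2C1=O` carries a different ester group: oxan-2-yl in place of 2-hydroxy-2-methyloctyl on a carbonyl carbon. For the measured compounds named here, only the step between compound 2 and compound 3 bears on this change, and it suggests that removing the long chain may recover some activity, though the ring is new here. Compound 4 is expected to give about 50000 nM, between 20000 nM and 150000 nM. The expected step is an at least 2.0-fold lower number from compound 3 to compound 4 (0.30 log units; that floor lies within the scatter).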

Compound 4, half-maximal inhibitory concentration: > 100000 nM
Compound 4: a limit, no number; the forecaster's own chance of this, stated with the estimate: 30%; at least 2.0-fold (0.30 log units) between middle value and limit.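

With oxan-2-yl on the carbonyl carbon, activity falls away compared with the two open-chain esters: there is an at least 3.3-fold higher number from compound 2 to compound 4 (0.51 log units; beyond the scatter), and an at least 2.4-fold higher number from compound 1 to compound 4 (0.38 log units; beyond the scatter). So a smaller group than 2-hydroxy-2-methyloctyl does not by itself bring back a readable value. Compound 4 gives a limit and not a number, as compound 3 does, so the step between them cannot be read: the limit of > 100000 nM in this assay, at which 2 of the 4 values shown sit.

Going by these compounds, whether closing the ring or lacking the hydroxyl group matters more stays open. An oxane ring carrying a hydroxyl group, or a piperidine ring with its amine in place of the ring oxygen, could help to separate these.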